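The compounds below may be only part of what the source reports. "The series", "measured", "known", "first", "only" and "open" are said of these compounds alone.

Working notes on the series.

Two compounds in the set have a number in a functional assay on LNCaP cells (Homo sapiens) for cytotoxicity, read by MTT assay, with a stated time of 48 h; a higher number here means a weaker inhibitor, a lower number a stronger inhibitor. Compound 1 `Cc1nc(-c2c[nH]c3ccccc23)co1` gives 316000 nM in this assay, and compound 2 `COc1ccc(-c2nc(-c3c[nH]c4ccccc34)co2)cc1OC` gives 278000 nM. Compound 1 stands as the higher of the two numbers, but the gap to compound 2 lies within the scatter, so the two compounds show the same level of activity as far as these numbers go; both sit at a weak level in this assay.

Compound 3 `C=Cc1nc(-c2c[nH]c3ccccc23)co1` is not yet measured. It differs from compound 1 by a single change: vinyl in place of methyl on an aromatic carbon of the shared core. Among the measured compounds shown here, no step between measured compounds of the set covers this change, and the only pair of numbers in hand, compound 1 against compound 2, does not touch this position. The change is small in what it counts, one carbon more and one double bond outside aromatic rings, and nothing in the measured numbers points in either direction.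

The step from compound 1 to compound 3 is therefore expected to be a 1.2-fold lower number from compound 1 to compound 3 (0.08 log units; within the scatter), not beyond the scatter. Compound 3 is estimated at 260000 nM in this assay, with a range from 110000 nM to 600000 nM.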

Compound 3, half-maximal inhibitory concentration: 530000 nM
Beside the measured number, compound 3's estimate is 2.0-fold (0.31 log units) below it, within the range that was stated.
By their numbers in this assay, from the lowest: compounds 2, 1 and 3 (each within the scatter of the next).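

Among the compounds shown here, the step from methyl to vinyl gives the first direct reading at this position: in this assay, the change gives a 1.7-fold higher number from compound 1 to compound 3 (0.22 log units; within the scatter), which lies within the scatter. On this aromatic carbon of a five-membered aromatic ring with 1 nitrogen and 1 oxygen, adding a carbon and a double bond outside aromatic rings therefore leaves compound 1 and compound 3 at the same weak level as far as these numbers go. Nothing in hand offers an account of this result at the position.

Still open, on these data alone, is whether a group of another kind at this same carbon, such as an amine, a carboxylic acid or a longer chain such as butyl, would carry the number beyond the scatter in either direction. One step in this assay also says nothing about changes elsewhere on the shared core, or about whether the vinyl for methyl change would read the same way in another assay.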